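The source may report more compounds than this note shows. Statements on the series, on what has been measured and on what is new or still open speak of the compounds shown alone.

Compound 1 `Cc1ccc(NS(=O)(=O)c2ccc(N3CCNC3=O)cc2)cc1` is one of three compounds that share the same core and differ only in the substituted phenyl ring on a sulfonamide nitrogen. In a functional assay on M21 cells (Homo sapiens) for antiproliferative activity, read by sulforhodamine B assay, with a stated time of 48 h (a higher number here means a weaker inhibitor, a lower number a stronger inhibitor), compound 1 gives 260 nM, the highest of the three numbers shown. Compound 2 `O=C1NCCN1c1ccc(S(=O)(=O)Nc2cccc(Br)c2)cc1` gives 59 nM and compound 3 `Cc1cc(C)cc(NS(=O)(=O)c2ccc(N3CCNC3=O)cc2)c1` gives 63 nM. The steps of a 4.4-fold lower number from compound 1 to compound 2 (0.64 log units; beyond the scatter) and a 4.1-fold lower number from compound 1 to compound 3 (0.62 log units; beyond the scatter) both move beyond the scatter, while a 1.1-fold higher number from compound 2 to compound 3 (0.03 log units; within the scatter) stays within it. Compound 4 `CCCCOc1ccc(NS(=O)(=O)c2ccc(N3CCNC3=O)cc2)cc1` differs from compound 1 in one place: butoxy in place of methyl on an aromatic carbon. Neither measured step bears directly on this change, since both swapped the whole phenyl ring for a differently substituted one, whereas compound 4 keeps the same substitution pattern and only exchanges the group itself. With no guidance from the data, no step beyond the scatter is expected in this assay in either direction, though a wide range is allowed. Compound 4 is estimated at 200 nM, between 60 nM and 700 nM, which means an expected step of a 1.3-fold lower number from compound 1 to compound 4 (0.11 log units; within the scatter).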

Compound 4, half-maximal inhibitory concentration: 580 nM
Compound 4: middle estimate off by 2.9-fold (0.46 log units), on the low side; the measured number falls inside the stated range.
By their numbers in this assay, from the lowest: compounds 2 and 3 (each within the scatter of the next); then compound 1; then compound 4.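

In this assay the exchange of methyl for butoxy gives a 2.2-fold higher number from compound 1 to compound 4 (0.35 log units; beyond the scatter) and so moves the number upward, whereas the changes to the phenyl ring seen so far both lowered it. This shows that the aromatic carbon para to a large group is not indifferent to what sits on it, and that a butoxy group there makes compound 4 a modestly weaker inhibitor than compound 1. No measurement available here explains the rise.

The compounds shown do not separate the oxygen from the length of the chain, which a methoxy group or a plain butyl chain on the same carbon could help to do. They also leave open how an amine or a carboxylic acid at this carbon would behave.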